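Compound 4: Same Carboxy Group, New Side Chain

The source may report more compounds than this note shows. Statements on the series, on what has been measured and on what is new or still open speak of the compounds shown alone.

Among the compounds with values here, in a functional assay on DU-145 cells (Homo sapiens) for cytotoxicity, read by trypan blue exclusion, with a stated time of 96 h (a lower number here means a stronger inhibitor, a higher number a weaker inhibitor), three compounds sharing one core have numbers so far. Compound 1 `COc1cc(OC)c(/C=C/S(=O)(=O)Cc2ccc(OC)c([N+](=O)[O-])c2)c(OC)c1`, which carries a nitro group, gives 2500 nM. Compound 2 `COC(=O)C(C)(C)Nc1cc(CS(=O)(=O)/C=C/c2c(OC)cc(OC)cc2OC)ccc1OC`, with (1-(methoxycarbonyl)-1-methylethyl)amino in place of that nitro group, gives 2500 nM, and the comparison shows no change at the digits printed from compound 1 to compound 2 (within the scatter). Compound 3 `COc1cc(OC)c(/C=C/S(=O)(=O)Cc2ccc(OC)c(NC(C)(C)C(=O)O)c2)c(OC)c1`, with (1-carboxy-1-methylethyl)amino there instead, gives 150 nM, the lowest number of the three and so the strongest inhibitor in this small set.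

The next structure is compound 4 `COc1cc(OC)c(/C=C/S(=O)(=O)Cc2ccc(OC)c(NC(C(=O)O)c3ccccc3)c2)c(OC)c1`, where carboxy(phenyl)methyl takes the place of 1-carboxy-1-methylethyl on a nitrogen on an aromatic ring: carboxy(phenyl)methyl in place of 1-carboxy-1-methylethyl on a nitrogen on an aromatic ring. The carboxy group stays. Within the data shown here, two measured steps bear on this, and both are large: a 17-fold lower number from compound 1 to compound 3 (1.22 log units; beyond the scatter), and, with hydrogen in place of methyl on an oxygen next to a carbonyl group, a 17-fold lower number from compound 2 to compound 3 (1.22 log units; beyond the scatter). The second of these suggests that compound 4, which keeps the free carboxy group, should stay nearer to compound 3 than to compound 2. Among the measured compounds shown here, no measured step tests a ring entering this chain, so the size of the change is uncertain. A modest weakening is expected in this assay, with an estimated step of a 2.3-fold higher number from compound 3 to compound 4 (0.37 log units; beyond the scatter). For compound 4 the estimate is 350 nM, with an expected range of 80 nM to 1500 nM.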

Compound 4, half-maximal inhibitory concentration: 20 nM
Estimate against measurement, compound 4: 18-fold (1.24 log units) above; the whole stated range lies above it.
By their numbers in this assay, from the lowest: compound 4; then compound 3; then compounds 1 and 2 (each within the scatter of the next).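

In this assay, the step of a 7.5-fold lower number from compound 3 to compound 4 (0.88 log units; beyond the scatter) shows that the group on this nitrogen can take a six-membered aromatic ring of carbon only, and that the number falls rather than rises when carboxy(phenyl)methyl replaces 1-carboxy-1-methylethyl. Within the data shown here, the earlier compounds showed only that a free carboxy group gave a far lower number than its methyl ester, whereas this result shows that the rest of the chain also matters while the carboxy group stays in place. The larger steps, a 130-fold lower number from compound 2 to compound 4 (2.10 log units; beyond the scatter) and a 130-fold lower number from compound 1 to compound 4 (2.10 log units; beyond the scatter), leave the phenyl-bearing compound as the strongest inhibitor of the four, though nothing measured here accounts for the gain.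

The methyl ester of the carboxy(phenyl)methyl chain is not among the compounds shown, so it remains open whether the ring changes the large effect seen in the step of a 17-fold lower number from compound 2 to compound 3 (1.22 log units; beyond the scatter). As far as these compounds go, it is equally open how a benzyl group, a longer chain between the nitrogen and the carboxylic acid, or a primary amide in place of that acid would behave at this position.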